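The compounds below may be only part of what the source reports. "The series", "measured", "known", "first", "only" and "open" are said of these compounds alone.

Measured compounds:
- compound 1 `O=S(=O)(NCCNc1nccc(-c2c(-c3cccc(F)c3)nc3sccn23)n1)c1ccc(F)cc1`: in a functional assay on A-375 cells (Homo sapiens) for cytotoxicity, read by MTT assay (a lower number here means a stronger inhibitor, a higher number a weaker inhibitor), compound 1 gives 9450 nM
- compound 2 `O=S(=O)(NCCCNc1nccc(-c2c(-c3cccc(F)c3)nc3sccn23)n1)c1ccc(C(F)(F)F)cc1`: in this assay compound 2 gives 4090 nM
- compound 3 `O=C(NCCNc1nccc(-c2c(-c3cccc(F)c3)nc3sccn23)n1)c1ccc(Cl)cc1`: in this assay compound 3 gives 2570 nM

Compound 3 holds the lowest number of the three; the gap to compound 2 lies within the scatter, the gap to compound 1 beyond it. The next compound, compound 4 `Cc1ccc(S(=O)(=O)NCCCNc2nccc(-c3c(-c4cccc(F)c4)nc4sccn34)n2)cc1`, differs from compound 3 by (((4-methylphenyl)sulfonyl)amino)methyl in place of ((4-chlorophenyl)carbonyl)amino on a saturated chain carbon, two bonds along the chain from a nitrogen on an aromatic ring.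

Two measured points bear on this. The step of a 3.7-fold lower number from compound 1 to compound 3 (0.57 log units; beyond the scatter) shows the carbonyl-for-sulfonyl exchange, here run in reverse, worth a modest move toward higher numbers. Like compound 4, a sulfonyl on the chain nitrogen is carried by compound 2, which gives 4090 nM, close to compound 3 and within its scatter. Taken together a small move toward a higher number in this assay is expected, near the edge of the scatter, with the step estimated as a 1.9-fold higher number from compound 3 to compound 4 (0.29 log units; within the scatter). The estimate for compound 4 is 5000 nM, with a range of 2000 nM to 12000 nM.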

Compound 4, half-maximal inhibitory concentration: 8380 nM
Compound 4: the middle estimate sits 1.7-fold (0.22 log units) below what was measured; measured number inside the range.
By their numbers in this assay, from the lowest: compounds 3 and 2 (each within the scatter of the next); then compounds 4 and 1 (each within the scatter of the next).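

In this assay, (((4-methylphenyl)sulfonyl)amino)methyl in place of ((4-chlorophenyl)carbonyl)amino gives a 3.3-fold higher number from compound 3 to compound 4 (0.51 log units; beyond the scatter), so compounds 1 and 4, both sulfonyl compounds, stand beyond the scatter from compound 3, while sulfonyl compound 2 goes against any general sulfonyl penalty. Methyl in place of trifluoromethyl on an aromatic carbon gives a 2.0-fold higher number from compound 2 to compound 4 (0.31 log units; beyond the scatter), the first reading of a change at this aromatic carbon, and it shows that the sulfonyl chain alone does not set the number. (((4-methylphenyl)sulfonyl)amino)methyl in place of ((4-fluorophenyl)sulfonyl)amino gives a 1.1-fold lower number from compound 1 to compound 4 (0.05 log units; within the scatter), so this exchange leaves the number within the scatter. No measurement shown gives a cause for these steps.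

Open, as far as these compounds go, is how a methoxy or a nitrile would read in place of methyl on that aromatic carbon. Also open, from the compounds shown here alone, is whether a carbonyl on a longer chain would keep the number of compound 3.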